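A few compounds are considered here, and "the series" means these few. Any claim that something is new, unique, unknown or untested is made for them only; others in the source may bear on it.

Among the measured compounds shown here, compound 1 `CCc1nc2c(-c3ccc(Cl)cc3Cl)ccnc2n1[C@@H](CC)C1CC1` is one of two compounds measured in an assay for binding affinity to Corticotropin releasing factor receptor (Rattus norvegicus); a lower number here means a stronger inhibitor, a higher number a weaker inhibitor. In this assay compound 1 gives 0.4 nM, the lower of the two numbers. The other, compound 2 `CCCC(C)n1c(CC)nc2c(-c3cc(F)c(F)cc3Cl)ccnc21`, differs from compound 1 in more than one place; in this assay compound 2 gives 2.4 nM, a higher number whose gap to compound 1 lies beyond the usual scatter. Compound 3 `CCc1nc2c(-c3ccc(Cl)cc3Cl)ccnc2n1[C@H](C)C1CC1` has not been measured. It differs from compound 1 in one place only: 1-cyclopropylethyl in place of 1-cyclopropylpropyl on an aromatic nitrogen. For the measured compounds named here, no measured pair here isolates this change, so the expectation rests on compound 1 alone. A small loss is expected, with the step from compound 1 to compound 3 estimated as a 2.5-fold higher number from compound 1 to compound 3 (0.40 log units; beyond the scatter), a step that could still fall within the scatter. For compound 3 the value in this assay is estimated at 1 nM, with a likely range from 0.3 nM to 4 nM.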

Compound 3, inhibition constant: 0.6 nM
Compound 3: the middle estimate sits 1.7-fold (0.22 log units) above what was measured; low and high end bracket the measured number.
By their numbers in this assay, from the lowest: compounds 1 and 3 (each within the scatter of the next); then compound 2.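

In this assay, replacing 1-cyclopropylpropyl with 1-cyclopropylethyl on the aromatic nitrogen gives a 1.5-fold higher number from compound 1 to compound 3 (0.18 log units; within the scatter), so compound 1 and compound 3 cannot be told apart. Among the compounds shown here, this is the first measured pair to isolate a change at this position, and it shows that a group of 5 heavy atoms can stand in for one of 6 without a measurable change, at least when the three-membered ring and one defined stereocentre are kept. No supporting data explain why the two groups give matching results.

From the compounds shown here alone, it remains open how far this tolerance extends, for instance to a longer chain, a phenyl ring, or a chain ending in an amine. The compounds shown also leave open what the opposite arrangement at the stereocentre would do.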